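Pyrrolidine substituent swap on a shared core: metabolic stability notes

The source may report more compounds than this note shows. Statements on the series, on what has been measured and on what is new or still open speak of the compounds shown alone.

Compound 1 `COc1ccc(-c2c(C)nc3c(N4CC[C@@H](NC(C)=O)C4)cc(Cl)nn23)cc1OC` has been run in an ADME assay on microsomes from liver (Homo sapiens) for metabolic stability, read by LC-MS, with NADPH named in the record, with a stated time of 60 min, tested at 1 uM, in the absence of a further agent; a lower number here means that less of the compound is left, a higher number that more of the compound is left. In this assay compound 1 reaches the limit > 95%, which is a limit of the assay and not a number. Compound 2 `COc1ccc(-c2c(C)nc3c(N4CC[C@@H](NC(=O)COc5ccccc5)C4)cc(C)nn23)cc1OC` shares the core and the pyrrolidine ring. In this assay compound 2 also reaches the limit > 95%, again a limit rather than a number. Among the compounds with values here, compound 2 therefore stands at the ceiling of what this assay reports, and the only other value known stands there too (the limit of > 95% in this assay, at which 2 of the 2 values shown sit). Within the data shown here, no step between measured compounds is available, so nothing has been learned about how changes on the saturated ring carbon move the read-out.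

Compound 3 `COc1ccc(-c2c(C)nc3c(N4CC[C@@H](n5cc(-c6ccccc6)nn5)C4)cc(C)nn23)cc1OC` differs from compound 2 in one place: 4-phenyl-1H-1,2,3-triazol-1-yl in place of ((phenoxymethyl)carbonyl)amino on a saturated ring carbon.

The step of a number at least 10 percentage points lower from compound 2 to compound 3 (that floor lies within the scatter) is estimated to be a small fall, possibly beyond the scatter. For compound 3 the estimate is 85%, within the range 55% to 97%.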

Compound 3, percent of the compound remaining: "unstable" (no number reported)
Nothing numeric was reported for compound 3, and the estimate cannot be compared.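

Within the data shown here, no step from compound 2 to compound 3 can be read in this assay: compound 3 has a word on record and no number. The compounds shown leave open how far the percent remaining shifts with 4-phenyl-1H-1,2,3-triazol-1-yl on the saturated ring carbon.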